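Adding chloro to compound 3

A few compounds are considered here, and "the series" means these few. Any claim that something is new, unique, unknown or untested is made for them only; others in the source may bear on it.

In a functional assay on U-251 cells (Homo sapiens) for inhibition, read by sulforhodamine B assay, with a stated time of 48 h (on this read-out lower numbers stand for stronger inhibition of growth and higher numbers for weaker inhibition of growth), compound 3 `CC(C)(C)NCc1c(C(=O)O)nn(-c2ccccc2)c1-c1ccc([N+](=O)[O-])cc1` has no exact number, only a limit of > 634000 nM. Compound 1 `CCOC(=O)c1nn(-c2ccccc2)c(-c2ccc([N+](=O)[O-])cc2)c1CNC(C)(C)C` shows 220000 nM; > 545000 nM (2 entries). Compound 2 `CC(C)(C)NCc1c(C(=O)O)nn(-c2ccccc2)c1-c1ccc(Br)cc1` gives 126000 nM. Compound 4 `CC(C)(C)NCc1c(C(=O)O)nn(-c2ccc(Cl)cc2)c1-c1ccc([N+](=O)[O-])cc1` takes chloro in place of hydrogen on an aromatic carbon, para to a large group (chloro in place of hydrogen on an aromatic carbon). For the measured compounds named here, no measured pair makes this same change. Going by the values given here, the one measured step, an at least 5.0-fold higher number from compound 2 to compound 3 (0.70 log units; beyond the scatter), lies beyond the scatter, but it puts nitro in place of bromo, so it bears only loosely. Among the compounds with values here, with that halogen-bearing comparison as the only guide, the estimated step is modest and toward stronger inhibition: an at least 1.5-fold lower number from compound 3 to compound 4 (0.20 log units; that floor lies within the scatter). For compound 4 the estimate is 400000 nM, with an expected range of 130000 nM to 750000 nM.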

Compound 4, concentration for 50% growth inhibition: > 583000 nM
Compound 4 ended at the assay's limit; the forecaster's own chance of this, stated with the estimate: 50%; middle value at least 1.4-fold (0.16 log units) from the limit.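

Compound 3 and compound 4 both give only limits rather than exact numbers, so the step between them cannot be read. On these data alone, whether chloro in place of hydrogen changes growth inhibition at all, and in which direction, stays open.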